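The source may report more compounds than this note shows. Statements on the series, on what has been measured and on what is new or still open speak of the compounds shown alone.

Of the compounds shown here, two with a shared core have been read in an ADME assay on microsomes from liver (Homo sapiens) for metabolic stability, read by LC-MS, with NADPH named in the record, with a stated time of 60 min, tested at 1 uM, in the absence of a further agent (on this read-out higher numbers stand for a more stable compound and lower numbers for a less stable compound), so far. Compound 1 (`COc1ccc(-c2c(C)nc3c(N4CC[C@@H](NC(=O)c5ccccc5)C4)cc(C)nn23)cc1OC`) gives > 95% as a limit of the assay and not a number. Compound 2 (`COc1ccc(-c2c(C)nc3c(N4CC[C@@H](SC(C)=O)C4)cc(C)nn23)cc1OC`) gives > 95% as a limit of the assay as well. Compound 2 therefore stands at the limit of > 95% in this assay, at which 2 of the 2 values shown sit, and has no exact figure.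

The next step leads to compound 3 (`COc1ccc(-c2c(C)nc3c(N4CC[C@@H](N=[N+]=[N-])C4)cc(C)nn23)cc1OC`), with azido in place of acetylsulfanyl on a saturated ring carbon. For the measured compounds named here, the only measured step bearing on it is a step that the two limits leave unreadable from compound 1 to compound 2 and it too exchanges one group on a saturated ring carbon. Its size cannot be read, so it gives only a weak hint that another exchange of this kind would leave the percent remaining high. No change beyond the usual scatter is therefore expected in this assay and any real movement could only be downward. The estimated change is a number at least 3 percentage points lower from compound 2 to compound 3 (that floor lies within the scatter) on this reasoning. In this assay the expected value for compound 3 is 92% within an estimated range of 72% to 100% and the result may again be only a limit.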

Compound 3, percent of the compound remaining: > 95%
Compound 3: a limit, no number; the forecaster's own chance of this, stated with the estimate: 50%; middle value at least 3 percentage points from the limit.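

In this assay compound 3 gives > 95%, a limit of the assay and not a number. For the compounds shown here, no step among compound 1, compound 2 and compound 3 can be read, since all three sit at one limit: the limit of > 95% in this assay, at which 3 of the 3 values shown sit. The compounds shown leave open whether any group on this saturated ring carbon would bring the percent remaining down from that limit.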